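The source may hold more compounds than are shown below. What is called first, only, known or untested is meant among the compounds shown, and "the series" means these compounds.

Measured in a functional assay on KM12 cells (Homo sapiens) for inhibition, read by sulforhodamine B assay, with a stated time of 48 h; on this read-out lower numbers stand for stronger inhibition of growth and higher numbers for weaker inhibition of growth:
compound 1, `O=CN1CCN(c2ccc(Cl)cc2)C1=S`, gives 12700 nM
compound 2, `COc1cc(C(=O)N2CCN(C=O)C2=S)cc(OC)c1OC`, gives 14400 nM
compound 3, `N#C/C(=C\N1CCN(C(=O)c2ccco2)C1=S)C(=O)Nc1ccc(Cl)cc1`, gives 16300 nM

Among the measured compounds shown here, compound 1 stands among three numbers that differ from one another by no more than the usual scatter of this assay; compounds 2 and 3 carry other groups on the shared core, and no single-point step between measured compounds is available. Compound 4, `O=CN1CCN(c2ccc(Cl)c(Cl)c2)C1=S`, differs from compound 1 by one change: chloro in place of hydrogen on an aromatic carbon. For the measured compounds named here, nothing among the measured compounds shows what such a change does on this core, so no direction can be argued from them; a step of size a 1.3-fold lower number from compound 1 to compound 4 (0.13 log units; within the scatter) is expected, which stays within the scatter. For compound 4 a value of 9500 nM is estimated, with a range from 4000 nM to 22000 nM.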

Compound 4, concentration for 50% growth inhibition: 15700 nM
For compound 4 the middle estimate is 1.7-fold (0.22 log units) below the measured one; the measured number falls inside the stated range.
By their numbers in this assay, from the lowest: compounds 1, 2, 4 and 3 (each within the scatter of the next).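

In this assay, among the compounds shown here, chloro in place of hydrogen on this aromatic carbon, ortho to a chloro group, gives a 1.2-fold higher number from compound 1 to compound 4 (0.09 log units; within the scatter), the first single-change reading on the shared core. At this position, then, a second chloro group does not separate compound 4 from compound 1 beyond the scatter. No measured evidence bears on why this step stays within the scatter. On these data alone, whether an amine or a carboxylic acid on the same aromatic carbon would give a step beyond the scatter remains open. So does the effect of replacing the chloro group already present in compound 1 with hydrogen.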